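From Methoxy to Ethyl: One Exchange on Compound 1

A few compounds are considered here, and "the series" means these few. Any claim that something is new, unique, unknown or untested is made for them only; others in the source may bear on it.

Compound 1, with the structure `COc1ccc(C(=O)N2CCN(Cc3nc4ccccc4n3Cc3cccc(C)c3)CC2)cc1`, was tested in an assay on isolated protein for inhibition of aldehyde dehydrogenase 1A1 (Homo sapiens), read by spectrophotometry, tested at 10 uM (a lower number here means less inhibition, a higher number more inhibition at the concentration tested (going by the name of the read-out)), and there compound 1 gives 55.5%. Among the compounds with values here, its only measured companion is compound 2, with the structure `Cc1cccc(Cn2c(OC3CCN(C(=O)c4ccco4)CC3)nc3ccccc32)c1`, and in this assay compound 2 gives 68.3%. Of the two numbers compound 1 holds the lower one, and the gap to compound 2 lies beyond the scatter of repeated measurements, so compound 2 inhibits more strongly at the concentration tested. The two compounds are not a single-point pair, so their gap tells nothing about any one group.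

Compound 3, with the structure `CCc1ccc(C(=O)N2CCN(Cc3nc4ccccc4n3Cc3cccc(C)c3)CC2)cc1`, differs from compound 1 in one place: ethyl in place of methoxy on an aromatic carbon. A methoxy leaves and an ethyl enters on an aromatic carbon of a six-membered aromatic ring of carbon only. Within the data shown here, no measured pair shows this exchange, so the expectation for compound 3 rests on compound 1 alone, and the step of a number 1.5 percentage points higher from compound 1 to compound 3 (within the scatter) is expected to stay within the scatter, with no clear direction. Compound 3 is accordingly estimated at 57%, in a range from 38% to 74%.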

Compound 3, a percentage reported as inhibition, at one concentration (the size of the read-out at that concentration, not a potency): 67%
The estimate for compound 3 lay 10 percentage points below the measured number; the measured number falls inside the stated range.
By their numbers in this assay, from the lowest: compound 1; then compounds 3 and 2 (each within the scatter of the next).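

In this assay, within the data shown here, the exchange of methoxy for ethyl, on an aromatic carbon para to a large group, gives the first step that can be read at a single place: a number 11.5 percentage points higher from compound 1 to compound 3 (beyond the scatter). This shows that the number responds to the group at this position, even though the count of heavy atoms stays the same and only the hydrogen-bond acceptor of the methoxy is lost. The 4-methoxyphenyl group is thus not needed to hold the inhibition at the concentration tested, and 4-ethylphenyl serves at least as well in this pair, but no measurement at hand bears on why the number rises.

The compounds shown leave open whether the number would keep rising with a longer chain such as propyl at the same place, and how a chlorine or an amine there would read. They also leave open whether the same exchange would give a similar step on another core, as it is seen here only on the core of compound 1 and at a single concentration, which gives the size of the inhibition and not a potency.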